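A few compounds are considered here, and "the series" means these few. Any claim that something is new, unique, unknown or untested is made for them only; others in the source may bear on it.

Compound 1 `C=C[C@@](C)(/C=C/c1ccc(O)c(/C=C/C#N)c1)CCC=C(C)C`: > 52000 nM
Compound 2 `COc1ccc(/C=C/[C@@](C)(/C=C/c2ccc(O)c(/C=C/C#N)c2)CCC=C(C)C)cc1`: > 26000 nM

Both compounds were tested in a functional assay on HepG2 cells (Homo sapiens) for cytotoxicity, with a stated time of 72 h; a higher number here means that more compound is needed for the effect, a lower number that less compound is needed. In this test, compound 2 gives > 26000 nM, which is a limit and not a number. Compound 1 also gives only a limit, > 52000 nM.

Compound 3 `COc1ccc(/C=C/[C@@](C)(/C=C/c2ccc(O)c(/C=C/C(=O)OC(C)(C)C)c2)CCC=C(C)C)cc1` differs from compound 2 at one place: tert-butoxycarbonyl in place of cyano on a double-bonded chain carbon bound to a double-bonded chain carbon. Within the data shown here, the only measured step is a step that the two limits leave unreadable from compound 1 to compound 2. It involves a different group, so it gives no size to carry over to this change. With compound 2 at the limit of > 26000 nM, compound 3 is expected to stay in the same region, with no step beyond the scatter in either direction, and it may again return only a limit. The expected step is a number no higher from compound 2 to compound 3 (the limit leaves the size open). For compound 3 the estimated value is 26000 nM, with an expected range from 9000 nM to 60000 nM.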

Compound 3, half-maximal effective concentration: > 52000 nM
Compound 3 was reported as a limit; the forecaster's own chance of this, stated with the estimate: 65%; middle value at least 2.0-fold (0.30 log units) from the limit.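

In this assay, compound 2 and compound 3 each return only a limit, so no step can be read between them, and the change from cyano to tert-butoxycarbonyl has no readable size. The compounds shown leave open what concentration any of them needs to reach the half-maximal effect.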